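Formyl in place of ethyl at the aryl end

The source may hold more compounds than are shown below. What is called first, only, known or untested is meant among the compounds shown, and "the series" means these compounds.

Of the compounds shown here, three sharing one core have been measured in a functional assay on HCT-15 cells (Homo sapiens) for inhibition, read by sulforhodamine B assay, with a stated time of 48 h, tested at 10 uM; on this read-out lower numbers stand for less inhibition and higher numbers for more inhibition at the one concentration tested (going by the name of the read-out). Compound 1 `Brc1ccc(-c2cn3ccnc3c(-c3ccc4ncn(C5CCCCC5)c4c3)n2)cc1` gives 35.8%. Compound 2 `c1csc(-c2cn3ccnc3c(-c3ccc4ncn(C5CCCCC5)c4c3)n2)c1` gives 2.33%, and the step of a number 33.5 percentage points lower from compound 1 to compound 2 (beyond the scatter) shows that swapping the aryl group on that aromatic carbon moves the read-out well beyond the scatter. Compound 3 `CCc1ccc(-c2cn3ccnc3c(-c3ccc4ncn(Cc5ccccc5)c4c3)n2)cc1` gives 74.7%, the highest of the three numbers, beyond the scatter above compound 1 and far above compound 2.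

Compound 4 `O=Cc1ccc(-c2cn3ccnc3c(-c3ccc4ncn(Cc5ccccc5)c4c3)n2)cc1` differs from compound 3 only at the ethyl group: formyl in place of ethyl on an aromatic carbon, on an aromatic carbon of a six-membered carbon ring, para to a large group. Among the compounds with values here, no measured step touches this exact change. Within the data shown here, the only step that bears on it is the one from compound 1 to compound 2, which alters the same aryl position and was large, so a change there is capable of shifting this assay substantially. Among the measured compounds shown here, with no direct precedent, a downward step of moderate size is expected, as a number 24.7 percentage points lower from compound 3 to compound 4 (beyond the scatter). Compound 4 is therefore estimated to give 50% in this assay, with a range from 20% to 80%.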

Compound 4, a percentage reported as inhibition, at one concentration (the size of the read-out at that concentration, not a potency): 49.1%
For compound 4 the middle estimate is 0.9 percentage points above the measured one; measured number inside the range.
By their numbers in this assay, from the lowest: compound 2; then compound 1; then compound 4; then compound 3.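

Where the step from compound 1 to compound 2 replaced a whole aryl group, this one leaves the phenyl ring in place and changes only the group on an aromatic carbon, para to a large group. In this assay, 4-ethylphenyl to 4-formylphenyl gives a number 25.6 percentage points lower from compound 3 to compound 4 (beyond the scatter), so the read-out responds to this position even though the count of heavy atoms stays the same, with a carbon giving way to an oxygen and a hydrogen-bond acceptor and a double bond entering. Nothing measured here explains why this exchange lowers the number, so the result stands as an observation about these two compounds only.

The compounds shown leave open how an amine, a carboxylic acid or a longer chain such as butyl would read at this same place, and so whether the drop follows from the formyl group itself or from any replacement of ethyl. They also leave open whether the same exchange would give a similar step with cyclohexyl in place of benzyl on the shared core.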